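Benzyloxy in place of phenyl: compound 4 awaits measurement

The compounds below may be only part of what the source reports. "The series", "measured", "known", "first", "only" and "open" are said of these compounds alone.

Measured so far in a functional assay on PBMC cells (Homo sapiens) for antiproliferative activity; on this read-out lower numbers stand for stronger inhibition and higher numbers for weaker inhibition:
- Compound 1 `CN(C(=O)Nc1ccc2c(-c3ccncc3)c[nH]c2c1)c1ccccc1`: 12000 nM
- Compound 2 `O=C(NOCc1ccccc1)Nc1ccc2c(-c3ccncc3)c[nH]c2c1`: 4600 nM
- Compound 3 `Cn1cc(C#N)c2ccc(NC(=O)Nc3ccccc3)cc21`: 14000 nM

In this assay, compound 3 gives 14000 nM, which lies within the usual scatter of compound 1 at 12000 nM. Compound 2 stands beyond the scatter from both, with the lower number 4600 nM.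

Compound 4 `Cn1cc(C#N)c2ccc(NC(=O)NOCc3ccccc3)cc21` keeps the core of compound 3 and carries benzyloxy in place of phenyl on an amide-type nitrogen.

Among the compounds with values here, one measured step bears on this change: a 2.6-fold lower number from compound 1 to compound 2 (0.42 log units; beyond the scatter). This modest step, beyond the scatter, puts (benzyloxy)amino in place of methyl(phenyl)amino on a carbonyl carbon. It is only a partial guide, since the group leaving there also holds a methyl and the core of compound 1 differs from that of compound 3. A step of similar size towards a lower number is therefore expected, though with wide uncertainty.

The estimated change is a 2.6-fold lower number from compound 3 to compound 4 (0.41 log units; beyond the scatter). For compound 4 the expected value is 5400 nM, with an estimated range from 2000 nM to 14000 nM.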

Compound 4, half-maximal inhibitory concentration: 17000 nM
For compound 4 the middle estimate is 3.1-fold (0.50 log units) below the measured one; measured number above the stated range.
By their numbers in this assay, from the lowest: compound 2; then compounds 1, 3 and 4 (each within the scatter of the next).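

In this assay, benzyloxy in place of phenyl on an amide-type nitrogen gives a 1.2-fold higher number from compound 3 to compound 4 (0.08 log units; within the scatter), so on the core of compound 3 this change leaves the number within the scatter. The earlier step, a 2.6-fold lower number from compound 1 to compound 2 (0.42 log units; beyond the scatter), lay beyond the scatter, but it was read on a different core and the group leaving there also held a methyl, so the lower number seen there does not carry over to the core of compound 3. Nothing at hand accounts for this difference between the two steps.

The compounds shown leave open whether a smaller methoxy group or a longer phenethyloxy chain on this nitrogen would move the number on the core of compound 3. They also leave open whether the lower number of compound 2 depends on its core or on the loss of the methyl.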